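The compounds below may be only part of what the source reports. "The series", "measured", "known", "first", "only" and "open" are said of these compounds alone.

Of the compounds shown here, three built on one shared core have been measured in an ADME assay on Caco-2 cells (Homo sapiens) for permeability, in the apical to basolateral direction; a higher number here means that the compound crosses the layer faster, a lower number that the compound crosses the layer more slowly. Compound 1 `C=C(C)C(=O)N1CCC(CN(C2Cc3cc(C#N)ccc3N(Cc3cncn3C)C2)S(=O)(=O)c2ccccn2)CC1` gives 0.5 10^-6 cm/s. Compound 2 `Cn1cnc(S(=O)(=O)N2CCC(CN(C3Cc4cc(C#N)ccc4N(Cc4cncn4C)C3)S(=O)(=O)c3ccccn3)CC2)c1` gives 0.1 10^-6 cm/s, while compound 3 `Cn1cncc1CN1CC(N(CC2CCN(C(=O)N3CCCC3)CC2)S(=O)(=O)c2ccccn2)Cc2cc(C#N)ccc21` gives 0.6 10^-6 cm/s. Among these three numbers compound 1 stands second highest: a 1.2-fold higher number from compound 1 to compound 3 (0.08 log units; within the scatter), whereas a 5.0-fold lower number from compound 1 to compound 2 (0.70 log units; beyond the scatter).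

Compound 4 `Cn1cncc1CN1CC(N(CC2CCN(C(=O)c3cccs3)CC2)S(=O)(=O)c2ccccn2)Cc2cc(C#N)ccc21` has not yet been measured in this assay. It differs from compound 1 in a single place: thiophen-2-yl in place of 1-methylethenyl on a carbonyl carbon. Cut one bond further out, the same change reads as (1-methylethenyl)carbonyl becoming (thiophen-2-yl)carbonyl, so the carbonyl on the ring nitrogen is kept and only the group on it is exchanged.

Two kinds of earlier step bear on this. Among the measured compounds shown here, the one change made on the same carbonyl carbon, a 1.2-fold higher number from compound 1 to compound 3 (0.08 log units; within the scatter), stayed within the scatter. The changes that removed the carbonyl altogether in favour of a sulfonyl, a 5.0-fold lower number from compound 1 to compound 2 (0.70 log units; beyond the scatter) and a 6.0-fold higher number from compound 2 to compound 3 (0.78 log units; beyond the scatter), were modest but beyond the scatter. Since compound 4 keeps the carbonyl, the expected outcome is a step of a 1.2-fold higher number from compound 1 to compound 4 (0.08 log units; within the scatter), that is, nothing beyond the scatter, in this assay. Compound 4 is therefore estimated at 0.6 10^-6 cm/s, with a likely range from 0.25 10^-6 cm/s to 1.5 10^-6 cm/s.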

Compound 4, apparent permeability: 0.5 10^-6 cm/s
Compound 4: middle estimate off by 1.2-fold (0.08 log units), on the high side; the measured number falls inside the stated range.
By their numbers in this assay, from the lowest: compound 2; then compounds 1, 4 and 3 (each within the scatter of the next).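

In this assay, the group on the carbonyl carbon has now been varied across 1-methylethenyl, pyrrolidin-1-yl and thiophen-2-yl, and the new five-membered aromatic ring with its sulfur atom leaves the result within the scatter: no change at the digits printed from compound 1 to compound 4 (within the scatter), and a 1.2-fold lower number from compound 3 to compound 4 (0.08 log units; within the scatter). Among the compounds shown here, the earlier compounds showed this tolerance for only one exchange on the carbonyl carbon, so compound 4 extends it to an aromatic ring, while the step to the sulfonyl compound is again beyond the scatter, at a 5.0-fold higher number from compound 2 to compound 4 (0.70 log units; beyond the scatter). Among these four compounds, only compound 2, with (1-methyl-1H-imidazol-4-yl)sulfonyl on the ring nitrogen, stands apart, and no measurement shown explains why the three carbonyl compounds stay together or why compound 2 differs.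

As far as these compounds go, it remains open whether a carboxylic acid or a primary amine attached to the carbonyl carbon would also stay within the scatter of these three carbonyl compounds. A plain methylsulfonyl group on the ring nitrogen would be needed to separate the sulfonyl link itself from the 1-methylimidazole ring it carries in compound 2.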